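This account rests on a few compounds, and the source may have more. Where it says the series, first, only, none or still open, it means among the compounds named here.

Measured compounds:

compound 1 `CC1=C(C(=O)OC(C)(C)C)C(c2cccs2)NC(=S)N1` — 26%
compound 2 `CC1=C(C(=O)OCc2ccccc2)C(c2cccs2)NC(=S)N1` — 45%
compound 3 `CC1=C(C(=O)OC(C)(C)C)C(c2cccs2)NC(=O)N1C` — 24%

All three were run in an assay on membranes from HEK293 cells for displacement of a labelled ligand from adenosine receptor A2b (Homo sapiens), read by scintillation counting, with a stated time of 30 min, tested at 1 uM; on this read-out lower numbers stand for less inhibition and higher numbers for more inhibition at the one concentration tested (going by the name of the read-out). Compound 1 and compound 2 share one core and differ only in one place: benzyl in place of tert-butyl on an oxygen next to a carbonyl group. This change gave a number 19 percentage points higher from compound 1 to compound 2 (beyond the scatter).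

Compound 3 carries a different core; the difference between the two cores is not broken down here. In this assay compound 3 gives 24%, which is within the scatter of compound 1 at 26%, so no order between these two can be read. Against compound 2 at 45% compound 3 stands clearly lower, but that gap mixes the core difference with the ester change and cannot be separated with the compounds at hand.

Compound 4 `CC1=C(C(=O)OCc2ccccc2)C(c2cccs2)NC(=O)N1C` is not yet measured in this assay. It stands to compound 3 as compound 2 stands to compound 1: benzyl in place of tert-butyl on an oxygen next to a carbonyl group. The place of the change reads the same in both pairs, so this is the same change on a second core.

Among the measured compounds shown here, the step expected here is a number 17 percentage points higher from compound 3 to compound 4 (beyond the scatter), resting on the single earlier instance of this change, which gave a number 19 percentage points higher from compound 1 to compound 2 (beyond the scatter). That it occurs only once, and on a different core, leaves the expected size uncertain. For compound 4 the estimated value is 41%, with a range from 26% to 56%.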

Compound 4, a percentage reported as inhibition, at one concentration (the size of the read-out at that concentration, not a potency): 50%
The estimate for compound 4 lay 9 percentage points below the measured number; the measured number falls inside the stated range.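

In this assay, benzyl in place of tert-butyl on an oxygen next to a carbonyl group gave a number 26 percentage points higher from compound 3 to compound 4 (beyond the scatter), so the rise seen on the core of compound 1 recurs on the core of compound 3. Set side by side, the two steps cannot be told apart in size, and in this series the change carries over from one core to the other with no measurable difference: the same change on two cores in this assay, a number 19 percentage points higher (beyond the scatter) from compound 1 to compound 2 and a number 26 percentage points higher (beyond the scatter) from compound 3 to compound 4, 7 percentage points apart, within the scatter of two such steps. This rests on two pairs, a single exchange of groups and two cores, so it does not show that the step would hold on any further core, and as a read-out at one concentration it gives no potency and no explanation for the rise.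

The compounds shown leave open how far the rise depends on benzyl itself, since only tert-butyl and benzyl appear at this place, and a longer chain, a phenethyl ester, a substituted benzyl or a carboxylic acid could each read differently. Also open, going by these compounds, is what the two cores contribute separately, as the difference between them is not broken down, and whether the thiophene ring common to all four compounds matters, which only a phenyl or furan ring in its place could test.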